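This account rests on a few compounds, and the source may have more. Where it says the series, first, only, none or still open, it means among the compounds named here.

For the measured compounds named here, compound 2 `C=C(Br)C(=O)Nc1cccc(-c2cn3nc(-c4ccc(C)cc4)sc3n2)c1` gives 1700 nM in a functional assay on CCRF-CEM cells (Homo sapiens) for inhibition, read by cell counting, with a stated time of 3 days (on this read-out higher numbers stand for weaker inhibition and lower numbers for stronger inhibition), the lowest of the two numbers so far; the nearest is compound 1 `C=C(Br)C(=O)Nc1cccc(-c2cn3nc(Cc4ccccc4)sc3n2)c1`, which in this assay gives 4200 nM. Going by the values given here, the single measured step runs a 2.5-fold lower number from compound 1 to compound 2 (0.39 log units; beyond the scatter), where a six-membered aromatic ring of carbon only, attached directly, took the place of the benzyl group. Compound 3 `C=C(Br)C(=O)Nc1cccc(-c2cn3nc(-c4cccs4)sc3n2)c1` differs from compound 2 by thiophen-2-yl in place of 4-methylphenyl on an aromatic carbon: a five-membered aromatic ring with 1 hetero atom, carrying 1 hydrogen-bond acceptor, replaces the six-membered aromatic ring of carbon only on an aromatic carbon of the shared core. Among the compounds with values here, no measured step exchanges one directly attached aromatic ring for another, so the step from compound 1 to compound 2 bears on this change only loosely, and the expected change in this assay is none beyond the scatter, with a slight lean toward a higher number. Compound 3 is accordingly expected to show a 1.5-fold higher number from compound 2 to compound 3 (0.17 log units; within the scatter). The estimated value of compound 3 in this assay is 2500 nM, within a range from 1000 nM to 6500 nM.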

Compound 3, half-maximal inhibitory concentration: 410 nM
Compound 3: the middle estimate sits 6.1-fold (0.79 log units) above what was measured, outside the stated range (below it).
By their numbers in this assay, from the lowest: compound 3; then compound 2; then compound 1.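

In this assay, this aromatic carbon of the shared core proves sensitive to the exchange of one directly attached aromatic ring for another: thiophen-2-yl in place of 4-methylphenyl gives a 4.1-fold lower number from compound 2 to compound 3 (0.62 log units; beyond the scatter). For the compounds shown here, this step is larger than the one seen earlier on replacing benzyl with 4-methylphenyl, and thiophen-2-yl in place of benzyl gives a 10-fold lower number from compound 1 to compound 3 (1.01 log units; beyond the scatter), the only step so far printed as large. No measurement offered here explains why the five-membered ring with its ring sulfur gives the lowest number of the three.

The compounds shown leave open whether the shift follows the ring sulfur, the five-membered ring or the loss of the methyl group from the six-membered ring. Unsubstituted phenyl, furan-2-yl and thiophen-3-yl at this carbon would help tell these apart.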